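Piperidine in Place of an Arylamine on the Shared Core

A few compounds are considered here, and "the series" means these few. Any claim that something is new, unique, unknown or untested is made for them only; others in the source may bear on it.

Measured compounds:
compound 1 `O=C1C(Nc2ccc(I)cc2)=CC(=O)c2c1nc1n2[C@H]2OC[C@@H](O)[C@H]2OC1`: 2530 nM
compound 2 `O=C1C(Nc2ccccc2F)=CC(=O)c2c1nc1n2[C@H]2OC[C@@H](O)[C@H]2OC1`: 2660 nM

In a functional assay on ECa-109 cells for inhibition, with ECa-109 cell line (Homo sapiens) as the target, read by sulforhodamine B assay (a lower number here means a stronger inhibitor, a higher number a weaker inhibitor), compound 1 gives 2530 nM. Compound 2 gives 2660 nM, and the change a 1.1-fold higher number from compound 1 to compound 2 (0.02 log units; within the scatter) leaves the two compounds indistinguishable, so compound 1 has the lowest of the two numbers without standing apart from compound 2. Compound 3 `O=C1C(N2CCCCC2)=CC(=O)c2c1nc1n2[C@H]2OC[C@@H](O)[C@H]2OC1` has not been measured. It differs from compound 1 by piperidin-1-yl in place of (4-iodophenyl)amino on a double-bonded ring carbon. Going by the values given here, the only step recorded so far, a 1.1-fold higher number from compound 1 to compound 2 (0.02 log units; within the scatter), exchanges one aryl group for another on the amine nitrogen and says little about replacing the whole (4-iodophenyl)amino group by piperidin-1-yl, which removes the hydrogen-bond donor. Among the compounds with values here, with no direct precedent, a moderate shift toward a higher number is expected, a 1.5-fold higher number from compound 1 to compound 3 (0.18 log units; within the scatter), though the range must stay wide. Compound 3 is therefore estimated at 3800 nM, between 1200 nM and 12000 nM.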

Compound 3, half-maximal inhibitory concentration: > 8000 nM
Compound 3: only a limit was reported (the forecaster's own chance of this, stated with the estimate: 10%); middle value at least 2.1-fold (0.32 log units) away from the limit.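

Swapping one aryl group for another on the amine nitrogen gave no readable change, a 1.1-fold higher number from compound 1 to compound 2 (0.02 log units; within the scatter), but this position does respond when the whole arylamino group is exchanged. In this assay, piperidin-1-yl in place of (4-iodophenyl)amino gives an at least 3.1-fold higher number from compound 1 to compound 3 (0.49 log units; beyond the scatter), and in place of (2-fluorophenyl)amino it gives an at least 3.0-fold higher number from compound 2 to compound 3 (0.47 log units; beyond the scatter), so both steps lie beyond the scatter. The reading for compound 3 is a limit and not a number: the limit of > 8000 nM in this assay, at which 1 of the 3 values shown sits.

This single change replaces an aromatic ring with a non-aromatic one and also removes the hydrogen-bond donor, and the compounds shown do not separate these two differences. Going by these compounds, how a cyclohexylamino group, which keeps the amine hydrogen on a non-aromatic ring, or a methyl(phenyl)amino group, which keeps the aromatic ring without that hydrogen, would read on this carbon remains open.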